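Cyano for methyl on the pyrimidine of a benzimidazole series

The source may report more compounds than this note shows. Statements on the series, on what has been measured and on what is new or still open speak of the compounds shown alone.

The series rests on a shared core, seen in compound 1 `Fc1ccc2nc(-c3cncnc3)n(C3CC3)c2c1` and compound 2 `Cc1ncncc1-c1nc2cc(F)c(F)cc2n1C1CC1`. In an ADME assay on cells for inhibition of cytochrome P450 11B1, mitochondrial (Homo sapiens), read by HPLC, with a stated time of 60 min (on this read-out lower numbers stand for stronger inhibition and higher numbers for weaker inhibition), compound 1 gives 5380 nM, and compound 2 gives 4160 nM. Compound 2 holds the lower of the two numbers, but its gap to compound 1 lies within the scatter, so the two compounds cannot be told apart on this read-out.

Compound 3 `N#Cc1ncncc1-c1nc2cc(F)c(F)cc2n1C1CC1` differs from compound 2 in one place: cyano in place of methyl on an aromatic carbon, the cyano sitting on an aromatic carbon of a six-membered aromatic ring with two nitrogens, next to the ring nitrogen, ortho to a large group and opposite the ring nitrogen. Going by the values given here, no measured pair in this set carries the same change, so there is no recorded step to lean on. The expectation for compound 3 is a modest move toward stronger inhibition, a step of a 2.1-fold lower number from compound 2 to compound 3 (0.32 log units; beyond the scatter), though a result indistinguishable from compound 2 would not be surprising. Compound 3 is estimated at 2000 nM in this assay, with a range from 600 nM to 6500 nM.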

Compound 3, half-maximal inhibitory concentration: 4990 nM
The estimate for compound 3 lay 2.5-fold (0.40 log units) below the measured number, within the range that was stated.
By their numbers in this assay, from the lowest: compounds 2, 3 and 1 (each within the scatter of the next).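

In this assay, the replacement of methyl by cyano gives a 1.2-fold higher number from compound 2 to compound 3 (0.08 log units; within the scatter), so at this position on the six-membered aromatic ring with two nitrogens, next to the ring nitrogen and ortho to a large group, the two groups cannot be told apart on this read-out. The change adds one heavy atom, a triple bond outside aromatic rings and a hydrogen-bond acceptor, yet compound 2 at 4160 nM and compound 3 at 4990 nM lie within the scatter of each other, which gives this position its first recorded step and shows no separation between these two groups. Nothing measured here offers an explanation for this result.

As far as these compounds go, what remains open is whether this position can separate any groups on this read-out, since methyl and cyano are the only two compared there on the shared core. An amine, a methoxy group or a carboxylic acid at the same place could show whether the numbers move beyond the scatter, or whether they stay as close as those of compound 2 and compound 3.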